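From Carbonyl to Benzyl on the Ring Nitrogen

The source may report more compounds than this note shows. Statements on the series, on what has been measured and on what is new or still open speak of the compounds shown alone.

Of the compounds shown here, two sharing one core have been measured in a functional assay on U2OS cells for antagonist activity at proto-oncogene Wnt-3 (Homo sapiens), read by a luciferase reporter, with a stated time of 18 h; a lower number here means that less compound is needed, a higher number that more compound is needed for the effect. Compound 1 `O=C1CC[C@@H](C(=O)N2CCC(NS(=O)(=O)c3cc(S(=O)(=O)c4ccccc4)ccc3C(F)(F)F)CC2)N1` gives 240 nM in this assay. Compound 2 `CN(C)c1ccc(C(=O)N2CCC[C@H]2C(=O)N2CCC(NS(=O)(=O)c3cc(S(=O)(=O)c4ccccc4)ccc3C(F)(F)F)CC2)cc1` stands at the higher of the two numbers: in this assay compound 2 gives 830 nM, a gap from compound 1 that lies beyond the usual scatter. Compound 3 `O=C([C@@H]1CCCN1Cc1ccccc1)N1CCC(NS(=O)(=O)c2cc(S(=O)(=O)c3ccccc3)ccc2C(F)(F)F)CC1` has not yet been measured. It differs from compound 2 in one place: benzyl in place of (4-(dimethylamino)phenyl)carbonyl on an amine nitrogen in a ring. The group that leaves carries two hydrogen-bond acceptors; the benzyl that enters carries none, and it sits on the amine nitrogen in a ring of the five-membered non-aromatic ring. Among the measured compounds shown here, no measured pair shows this change, so its size cannot be read from the data; the expectation is a modest step in this assay, direction unsettled, quite possibly none beyond the scatter. The change is estimated as a 1.4-fold lower number from compound 2 to compound 3 (0.14 log units; within the scatter). Compound 3 is expected to give 600 nM, within 200 nM to 2500 nM.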

Compound 3, half-maximal effective concentration: 720 nM
Beside the measured number, compound 3's estimate is 1.2-fold (0.08 log units) below it, within the range that was stated.
By their numbers in this assay, from the lowest: compound 1; then compounds 3 and 2 (each within the scatter of the next).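

In this assay the ring nitrogen of the five-membered non-aromatic ring does not separate the two groups: the exchange of (4-(dimethylamino)phenyl)carbonyl for benzyl gives a 1.2-fold lower number from compound 2 to compound 3 (0.06 log units; within the scatter) and so stays within the scatter, even though benzyl has no hydrogen-bond acceptors. The exchange on the carbonyl carbon, 1-benzylpyrrolidin-2-yl in place of 5-oxopyrrolidin-2-yl, gives a 3.0-fold higher number from compound 1 to compound 3 (0.48 log units; beyond the scatter) and so lies beyond the scatter, which places the larger readable difference at that exchange rather than between the two nitrogen groups. Nothing at hand accounts for either result.

Going by these compounds, it remains open whether a methyl or acetyl group on that ring nitrogen, or the free amine, would bring the number closer to that of compound 1. On these data alone, it is also open how a benzyl carrying a carboxylic acid would read.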